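Swapping One Hydroxyphenyl Group for Another at the Limit

The compounds below may be only part of what the source reports. "The series", "measured", "known", "first", "only" and "open" are said of these compounds alone.

Three related compounds have been tested in an ADME assay on RAW264.7 cells (Mus musculus) for cytotoxicity, read by MTT assay (a lower number here means a stronger inhibitor, a higher number a weaker inhibitor), and none of them has yielded a number. Compound 1 (`CCCCCCCCCCCCCCCCCCOc1cccc(O)c1C(=O)/C=C/c1ccc(O)cc1`) reads > 30000 nM as a limit of the assay. Compound 2 (`O=C(/C=C/c1ccc(O)cc1)c1c(O)cccc1OCc1ccccc1`) reads > 30000 nM as a limit too. Compound 3 (`CCCCCCCCCCOc1cccc(O)c1C(=O)/C=C/c1ccc(O)c(Cl)c1`) reads > 30000 nM as a limit as well. Compound 3 therefore has no number of its own and stands where the other two stand (the limit of > 30000 nM in this assay, at which 3 of the 3 values shown sit).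

Compound 4 (`CCCCCCCCCCOc1cccc(O)c1C(=O)/C=C/c1ccccc1O`) has not yet been measured. It carries 2-hydroxyphenyl in place of the 3-chloro-4-hydroxyphenyl of compound 3, on a double-bonded chain carbon bound to a double-bonded chain carbon (2-hydroxyphenyl in place of 3-chloro-4-hydroxyphenyl on a double-bonded chain carbon bound to a double-bonded chain carbon). Among the compounds with values here, no measured pair shows what such an exchange does in this assay so no direction is favoured, and no change beyond the usual scatter is expected. This expectation rests on compound 3, whose > 30000 nM is a limit. The estimated step (a step that the limit leaves unreadable from compound 3 to compound 4) is accordingly small. Compound 4 is expected to read near 35000 nM with an estimated range from 15000 nM to 80000 nM and the assay may well report only a limit once more.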

Compound 4, half-maximal inhibitory concentration: > 30000 nM
Compound 4 gave a limit, no number; the forecaster's own chance of this, stated with the estimate: 75%; the middle value lies beyond the limit too.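

Compound 3 and compound 4 both sit at a limit in this assay, so the exchange of 3-chloro-4-hydroxyphenyl for 2-hydroxyphenyl gives no readable step: the limit of > 30000 nM in this assay, at which 4 of the 4 values shown sit. The compounds shown leave open whether any of their differences, in the chain or in the aromatic group, changes the reading in this assay at all.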